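Propyl to isopropyl at the saturated ring carbon

The compounds below may be only part of what the source reports. "The series", "measured", "known", "first", "only" and "open" are said of these compounds alone.

Measured so far:
- compound 1 `Cc1n[nH]cc1-c1cc2c(s1)C(=O)N[C@]1(CC[C@@](O)(c3ccc(F)cc3)CC1)N2`: 130 nM
- compound 2 `CCCC1(C)NC(=O)c2sc(-c3ccncc3)cc2N1`: 33 nM
- compound 3 `CN1C(=O)c2sc(-c3ccncc3)cc2NC1(C)C`: 240 nM

In an assay for inhibition of Rho-associated protein kinase 1 (Homo sapiens), read by TR-FRET, with stated times of 5 min and 2 h (on this read-out lower numbers stand for stronger inhibition and higher numbers for weaker inhibition), compound 2 gives the lowest number of the three measured. The nearest is compound 1, whose value is higher by a margin beyond the usual scatter, and compound 3 stands further off still; compound 2 can therefore be called the most potent of the three. Compound 3 differs from compound 2 in more than one place, so no single change can be read from the gap between them.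

The next compound in the series is compound 4 `CC(C)C1(C)NC(=O)c2sc(-c3ccncc3)cc2N1`. Compared with compound 2 it has the same atoms joined differently: isopropyl in place of propyl on a saturated ring carbon. Both the leaving and the entering group carry no donor, no acceptor and no charge, and the site is the same saturated ring carbon between two ring nitrogen atoms.

Among the measured compounds shown here, no measured pair in the set isolates this change, so there is no step to lean on. The expected step is estimated as a 1.4-fold higher number from compound 2 to compound 4 (0.13 log units; within the scatter). Compound 4 is estimated at 45 nM in this assay, with a range from 15 nM to 150 nM.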

Compound 4, half-maximal inhibitory concentration: 35 nM
For compound 4 the middle estimate is 1.3-fold (0.11 log units) above the measured one; the measured number falls inside the stated range.
By their numbers in this assay, from the lowest: compounds 2 and 4 (each within the scatter of the next); then compounds 1 and 3 (each within the scatter of the next).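

In this assay, isopropyl in place of propyl on the saturated ring carbon gives a 1.1-fold higher number from compound 2 to compound 4 (0.03 log units; within the scatter), so this pair gives no sign that the two chains differ at this position. Among the compounds shown here, this is the first comparison that isolates a single change, and it shows that the same carbon count joined differently, with no donor, acceptor or charge on either group, leaves the number within the scatter. Nothing measured bears on why the two chains read alike here.

Still open, going by these compounds, is whether the tolerance seen with these two chains extends to groups of another kind on this carbon, such as a cyclohexyl ring, a longer chain ending in an amine, or a carboxylic acid. Compound 1 and compound 3 each differ from compound 2 and compound 4 in more than one place, so their gaps to those compounds cannot be read as steps, and the contributions of the ring amide nitrogen substituent and the aromatic group remain unresolved.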